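The source may hold more compounds than are shown below. What is called first, only, known or untested is meant among the compounds shown, and "the series" means these compounds.

Three compounds have been measured in a functional assay on HT-29 cells (Homo sapiens) for cytotoxicity, read by MTT assay, with a stated time of 72 h; a lower number here means a stronger inhibitor, a higher number a weaker inhibitor:

compound 1 `COc1cc(Nc2cc(Nc3ccc(Oc4ccncc4-c4cccnc4)c(F)c3)ncn2)cc(OC)c1`: 1130 nM
compound 2 `COc1ccc(-n2nc(C(=O)Nc3ccc(Oc4ccncc4-c4cccnc4)c(F)c3)c(=O)n(C)c2=O)c(OC)c1`: 890 nM
compound 3 `O=C(Nc1ccc(Oc2ccncc2-c2cccnc2)c(F)c1)C1=NN(c2ccccc2C(F)(F)F)c2ccccc2S1(=O)=O`: 190 nM

All three carry the same amide-linked aryl ether core, and they differ in what is attached to it. Compound 3 stands lowest of the three numbers in this assay; compound 2 is nearest with a number beyond the scatter above it, and compound 1 is furthest, also beyond the scatter. So compound 3 is the strongest inhibitor of the three measured.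

Compound 4 `O=C(Nc1ccc(Oc2ccncc2-c2cccnc2)c(F)c1)C1=NN(c2cccc(F)c2)c2ccccc2S1(=O)=O` has not yet been measured. It keeps the whole of compound 3 apart from one change: 3-fluorophenyl in place of 2-(trifluoromethyl)phenyl on a nitrogen on an aromatic ring in a ring. The group on that ring nitrogen is exchanged, with the rest of the fused two-ring system and the shared core untouched.

Within the data shown here, no measured pair shows this kind of exchange, so the data give no step to lean on. Compound 4 is expected to stay close to compound 3, with a step of a 1.5-fold higher number from compound 3 to compound 4 (0.17 log units; within the scatter) that is most likely within the scatter, and possibly a small loss. Compound 4 is therefore estimated at 280 nM, within the range 90 nM to 900 nM.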

Compound 4, half-maximal inhibitory concentration: 430 nM
Estimate against measurement, compound 4: 1.5-fold (0.19 log units) below; the range from low to high includes it.
By their numbers in this assay, from the lowest: compound 3; then compound 4; then compounds 2 and 1 (each within the scatter of the next).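

In this assay the group on the ring nitrogen affects the result: replacing 2-(trifluoromethyl)phenyl with 3-fluorophenyl gives a 2.3-fold higher number from compound 3 to compound 4 (0.35 log units; beyond the scatter), a modest step that lies beyond the usual scatter. Among these compounds, the earlier compounds differed from one another in more than one place, so this pair gives the first direct reading of a single change, with the rest of the molecule held constant. Nothing measured here explains the step.

The two phenyl groups differ both in their substituent and in where it sits on the ring, so this one pair cannot separate those two differences. On these data alone, it also remains open how the position would respond to something other than a substituted phenyl, such as an amine, a carboxylic acid or a longer alkyl chain.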